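A few compounds are considered here, and "the series" means these few. Any claim that something is new, unique, unknown or untested is made for them only; others in the source may bear on it.

Compound 3 `CC(C(=O)NCc1ccc(C(F)(F)F)nc1N1CCC(c2ccccc2)CC1)c1ccc(NS(C)(=O)=O)c(F)c1` gives 0.6 nM in a functional assay on CHO-K1 cells for antagonist activity at transient receptor potential cation channel subfamily V member 1 (Homo sapiens), read by FLIPR; on this read-out higher numbers stand for weaker inhibition and lower numbers for stronger inhibition. Among the three compounds measured so far it holds the second highest number: compound 2 `CC(C(=O)NCc1ccc(C(F)(F)F)nc1N1CC=CCC1)c1ccc(NS(C)(=O)=O)c(F)c1`, with 0.3 nM, sits within the scatter of it, as the step of a 2.0-fold higher number from compound 2 to compound 3 (0.30 log units; within the scatter) shows, while compound 1 `CC(C(=O)NCc1ccc(C(F)(F)F)nc1NCc1ccc(Cl)cc1)c1ccc(NS(C)(=O)=O)c(F)c1`, with 65.7 nM, lies far beyond it, the step being a 110-fold lower number from compound 1 to compound 3 (2.04 log units; beyond the scatter). Compound 4 `CC(C(=O)NCc1ccc(C(F)(F)F)nc1N1CCCCCC1)c1ccc(NS(C)(=O)=O)c(F)c1` has not yet been measured. It differs from compound 3 in one place: azepan-1-yl in place of 4-phenylpiperidin-1-yl on an aromatic carbon. For the measured compounds named here, two measured steps bear on this change. The step of a 220-fold lower number from compound 1 to compound 2 (2.34 log units; beyond the scatter) shows that a six-membered non-aromatic ring in place of (4-chlorobenzyl)amino brings a large drop in the number, and the step of a 2.0-fold higher number from compound 2 to compound 3 (0.30 log units; within the scatter) shows that adding a phenyl group to such a ring changes little. Compound 4 keeps a non-aromatic ring on the same aromatic carbon and only loses the phenyl, so the expected step in this assay is a 1.5-fold lower number from compound 3 to compound 4 (0.18 log units; within the scatter), a move that should stay within the scatter. Compound 4 is therefore estimated to give about 0.4 nM, most likely between 0.15 nM and 1.5 nM.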

Compound 4, inhibition constant: 0.8 nM
For compound 4 the middle estimate is 2.0-fold (0.30 log units) below the measured one, within the range that was stated.
By their numbers in this assay, from the lowest: compounds 2, 3 and 4 (each within the scatter of the next, the first and the last beyond it); then compound 1.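

In this assay, the aromatic carbon next to the ring nitrogen also accepts a seven-membered non-aromatic ring: azepan-1-yl in place of (4-chlorobenzyl)amino gives a large step (an 82-fold lower number from compound 1 to compound 4 (1.91 log units; beyond the scatter)), so among these compounds the benefit is not confined to six-membered rings. Azepan-1-yl and 4-phenylpiperidin-1-yl cannot be told apart (a 1.3-fold higher number from compound 3 to compound 4 (0.12 log units; within the scatter)), even though azepan-1-yl has fewer heavy atoms. For the compounds shown here, the six-membered ring of compound 2 and the seven-membered ring of compound 4 do separate, but only modestly (a 2.7-fold higher number from compound 2 to compound 4 (0.43 log units; beyond the scatter)), the first step beyond the scatter among the compounds carrying a non-aromatic ring here.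

Nothing available explains these steps. From the compounds shown here alone, whether a morpholine ring, a pyrrolidine ring or an open-chain diethylamino group would work equally well at this position remains open.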